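An Ethyl Group Added to a Phenyl Ketone Diacid

A few compounds are considered here, and "the series" means these few. Any claim that something is new, unique, unknown or untested is made for them only; others in the source may bear on it.

Measured compounds:
compound 1, `O=C(O)CSC(CC(=O)c1ccccc1)C(=O)O`, 15000 nM
compound 2, `Cc1ccc(C(=O)CC(SCC(=O)O)C(=O)O)cc1C`, 3810 nM
compound 3, `Cc1ccc(C)c(C(=O)CC(SCC(=O)O)C(=O)O)c1`, 2680 nM

In a functional assay on HeLa cells (Homo sapiens) (on this read-out higher numbers stand for weaker inhibition and lower numbers for stronger inhibition), compound 1 gives the highest number of the three measured compounds. Compound 2 and compound 3, which each carry two methyl groups on the ring, both give lower numbers than compound 1, and both gaps lie beyond the scatter. Compound 4 `CCc1ccc(C(=O)CC(SCC(=O)O)C(=O)O)cc1` differs from compound 1 in one place: ethyl in place of hydrogen on an aromatic carbon. For the measured compounds named here, no measured pair isolates this single change, so its size must be estimated. A downward step of moderate size, beyond the scatter, is expected from compound 1 to compound 4 in this assay, namely a 3.0-fold lower number from compound 1 to compound 4 (0.48 log units; beyond the scatter). Compound 4 is accordingly estimated at 5000 nM, with a range from 2000 nM to 12000 nM.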

Compound 4, half-maximal inhibitory concentration: 4790 nM
For compound 4 the middle estimate is 1.0-fold (0.02 log units) above the measured one; low and high end bracket the measured number.
By their numbers in this assay, from the lowest: compounds 3, 2 and 4 (each within the scatter of the next); then compound 1.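

In this assay, ethyl in place of hydrogen on an aromatic carbon, para to a large group, gives a 3.1-fold lower number from compound 1 to compound 4 (0.50 log units; beyond the scatter). For the compounds shown here, this is the first step that isolates one change, showing that a single ring substituent at this position is enough to move the number beyond the scatter. No measurement at hand explains the step. As far as these compounds go, whether a methyl, a longer chain such as propyl, an amine or a carboxylic acid at this position would lower the number further or raise it remains open, as does the effect of ethyl on other ring carbons.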